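Replacing 1-methylpiperidin-4-yl with pyridin-4-yl on the shared core

The source may report more compounds than this note shows. Statements on the series, on what has been measured and on what is new or still open speak of the compounds shown alone.

Measured in a functional assay on A2780 cells (Homo sapiens) for antiproliferative activity, read by fluorescence, with a stated time of 72 h; on this read-out higher numbers stand for weaker inhibition and lower numbers for stronger inhibition:
compound 1 `CC(C)(C)C(=O)N1Cc2c(NC(=O)c3cccnc3)n[nH]c2C1(C)C` gives 690 nM
compound 2 `CC(C)(C)C(=O)N1Cc2c(NC(=O)c3ccc(F)cc3)n[nH]c2C1(C)C` gives 270 nM
compound 3 `CN1CCC(C(=O)Nc2n[nH]c3c2CN(C(=O)C(C)(C)C)C3(C)C)CC1` gives 350 nM

The three compounds share one core and differ only in the group on a carbonyl carbon. Compound 3 lies within the scatter of both neighbours, with a 2.0-fold lower number from compound 1 to compound 3 (0.29 log units; within the scatter) and a 1.3-fold higher number from compound 2 to compound 3 (0.11 log units; within the scatter). Only a 2.6-fold lower number from compound 1 to compound 2 (0.41 log units; beyond the scatter) goes beyond the scatter, and it is modest.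

The next compound is compound 4 `CC(C)(C)C(=O)N1Cc2c(NC(=O)c3ccncc3)n[nH]c2C1(C)C`, where pyridin-4-yl stands in place of 1-methylpiperidin-4-yl on a carbonyl carbon: pyridin-4-yl in place of 1-methylpiperidin-4-yl on a carbonyl carbon. Within the data shown here, no pyridin-4-yl compound has been measured yet, so the closest guide is compound 1 , which carries pyridin-3-yl at that place and gives 690 nM. The step to compound 3 from that pyridine, a 2.0-fold lower number from compound 1 to compound 3 (0.29 log units; within the scatter), suggests that going back to a pyridine in this assay could give a slightly higher number, though probably not one clearly beyond the scatter. The modest size of a 2.6-fold lower number from compound 1 to compound 2 (0.41 log units; beyond the scatter) also argues against expecting a large move from a change at this carbonyl carbon.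

The expected change is a 1.7-fold higher number from compound 3 to compound 4 (0.23 log units; within the scatter). For compound 4 the estimated value is 600 nM, with an expected range from 250 nM to 1300 nM.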

Compound 4, half-maximal inhibitory concentration in the A2780 assay: 110 nM
Estimate against measurement, compound 4: 5.5-fold (0.74 log units) above, outside the stated range (below it).
By their numbers in the A2780 assay, from the lowest: compound 4; then compounds 2, 3 and 1 (each within the scatter of the next, the first and the last beyond it).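

Among these compounds, in the A2780 assay, pyridin-4-yl and pyridin-3-yl prove not to be interchangeable on this carbonyl carbon, with a 6.3-fold lower number from compound 1 to compound 4 (0.80 log units; beyond the scatter), so the identity of the pyridine at this place matters in a way the earlier compounds could not show. Among the compounds shown here, compound 4 also separates from the two non-pyridine compounds, with a 3.2-fold lower number from compound 3 to compound 4 (0.50 log units; beyond the scatter) and a 2.5-fold lower number from compound 2 to compound 4 (0.39 log units; beyond the scatter), making it the most potent of the four, the only compound whose steps to all the others lie beyond the scatter. In a physicochemical assay for solubility, at pH 7 (on this read-out lower numbers stand for lower solubility and higher numbers for higher solubility), compound 3 gives > 225000 nM, which is a limit of the assay and not a number: the limit of > 225000 nM in the physicochemical assay, at which 1 of the 2 values shown sits.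

Going by these compounds, in the physicochemical assay compound 4 gives 205000 nM, but the step from compound 3 cannot be read, so it remains open whether the two compounds differ on that read-out. The compounds shown also leave open how pyridin-2-yl would compare at this carbonyl carbon, and whether an amine or a methoxy group on the pyridin-4-yl ring would keep the number seen for compound 4.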